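The source may report more compounds than this note shows. Statements on the series, on what has been measured and on what is new or still open speak of the compounds shown alone.

The measured compounds:
Compound 1 `CC(NC(=O)/C=C/c1ccc(NC(=O)Nc2ccc(Cl)c(C(F)(F)F)c2)cc1)c1ccccc1` gives 3130 nM in a functional assay on MX1 cells (Homo sapiens) for inhibition, read by MTT assay, with a stated time of 120 h; on this read-out lower numbers stand for stronger inhibition and higher numbers for weaker inhibition.
Compound 2 `CC(NC(=O)c1ccc(-c2ccc(NC(=O)Nc3cc(C(F)(F)F)ccc3Cl)cc2)cc1)c1ccccc1` gives 17700 nM.
Compound 3 `CC1CN(C(=O)/C=C/c2ccc(NC(=O)Nc3ccc(Cl)c(C(F)(F)F)c3)cc2)CC(C)O1` gives 12800 nM.

Compound 1 and compound 3 share a core and differ in one place: 2,6-dimethylmorpholin-4-yl in place of (1-phenylethyl)amino on a carbonyl carbon. This change gave a 4.1-fold higher number from compound 1 to compound 3 (0.61 log units; beyond the scatter). Compound 2 sits on a different core; how the two cores differ is not broken down here. Compound 2 gives the highest of the three numbers, and its number lies within the scatter of that of compound 3, so no order between those two can be read.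

Compound 4 `CC1CN(C(=O)c2ccc(-c3ccc(NC(=O)Nc4cc(C(F)(F)F)ccc4Cl)cc3)cc2)CC(C)O1` is not yet measured. It differs from compound 2 in one place: 2,6-dimethylmorpholin-4-yl in place of (1-phenylethyl)amino on a carbonyl carbon. This is the same kind of change as that from compound 1 to compound 3, though the carbonyl carbon sits on an aromatic carbon here and on a double-bonded chain carbon there. Resting on a 4.1-fold higher number from compound 1 to compound 3 (0.61 log units; beyond the scatter), a step of about the same size is expected from compound 2 to compound 4, that is a 2.8-fold higher number from compound 2 to compound 4 (0.45 log units; beyond the scatter). Because compound 2 already gives 17700 nM, the number for compound 4 is estimated at 50000 nM, between 18000 nM and 150000 nM.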

Compound 4, half-maximal inhibitory concentration: > 50000 nM
Compound 4 ended at the assay's limit; the forecaster's own chance of this, stated with the estimate: 30%; the middle value sits exactly at the limit.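

In this assay compound 4 gives > 50000 nM, which is a limit of the assay and not a number. Replacing (1-phenylethyl)amino with 2,6-dimethylmorpholin-4-yl on a carbonyl carbon gives an at least 2.8-fold higher number from compound 2 to compound 4 (0.45 log units; beyond the scatter), so inhibition weakens on both cores shown, although two cores are too few to make this a rule for the series. The direction of the change therefore carries over here, but its size cannot be compared: the same change on two cores in this assay, a 4.1-fold higher number (0.61 log units; beyond the scatter) from compound 1 to compound 3 and an at least 2.8-fold higher number (0.45 log units; beyond the scatter) from compound 2 to compound 4; the limit leaves it open whether they differ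

The compounds shown leave open how much of each step comes from the methyl groups of the morpholine ring and how much from the loss of the (1-phenylethyl)amino group. Placing an unsubstituted morpholin-4-yl or a benzylamino group on the same carbonyl carbon of each core would help separate these parts, and a measured number rather than a limit on the core of compound 2 would allow the sizes to be compared.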